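The source may hold more compounds than are shown below. What is called first, only, known or untested is meant among the compounds shown, and "the series" means these compounds.

Working notes on the series built around the shared core of compound 1 `CC(C)n1c(S)nnc1Sc1nnc(-c2ccccc2)n1-c1ccccc1`, in which the group on one of the triazole nitrogens is varied. Compound 1 carries an isopropyl there, and in a functional assay on MDA-MB-231 cells (Homo sapiens) for inhibition, read by MTT assay, with a stated time of 48 h (a lower number here means a stronger inhibitor, a higher number a weaker inhibitor), compound 1 gives "not determined" (no result reported). Compound 2 `Fc1ccc(-n2c(S)nnc2Sc2nnc(-c3ccccc3)n2-c2ccccc2)cc1` carries a 4-fluorophenyl and in this assay gives 29700 nM. For the measured compounds named here, compound 3 `CCOc1ccc(-n2c(S)nnc2Sc2nnc(-c3ccccc3)n2-c2ccccc2)cc1` carries a 4-ethoxyphenyl and in this assay gives 43900 nM, the highest of the two numbers so far; the only step measured, a 1.5-fold higher number from compound 2 to compound 3 (0.17 log units; within the scatter), stays within the scatter, so the two aryl-bearing compounds are not separated.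

Compound 4 `Sc1nnc(Sc2nnc(-c3ccccc3)n2-c2ccccc2)n1-c1ccc(Cl)cc1` is the next member. Relative to compound 3 the change is chloro in place of ethoxy on an aromatic carbon. Going by the values given here, the one measured step that bears on it is the exchange at the same aromatic carbon from fluoro to ethoxy, a 1.5-fold higher number from compound 2 to compound 3 (0.17 log units; within the scatter), which did not move the number beyond the scatter. Going from ethoxy to another halogen, chloro, is therefore expected to give at most a small step, if any, in this assay, and the direction cannot be read from the two numbers in hand.

For compound 4 the expected value in this assay is 30000 nM, with a range of 12000 nM to 80000 nM, corresponding to an estimated step of a 1.5-fold lower number from compound 3 to compound 4 (0.17 log units; within the scatter).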

Compound 4, half-maximal inhibitory concentration: 49700 nM
Beside the measured number, compound 4's estimate is 1.7-fold (0.22 log units) below it, and the stated range covers the measured number.
By their numbers in this assay, from the lowest: compounds 2, 3 and 4 (each within the scatter of the next).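

In this assay the step of a 1.1-fold higher number from compound 3 to compound 4 (0.05 log units; within the scatter) and the step of a 1.7-fold higher number from compound 2 to compound 4 (0.22 log units; within the scatter) both stay within the scatter, so chloro, at the aromatic carbon para to a large group, is not separated from either ethoxy or fluoro. This position now holds three different groups, and exchanging the ethoxy chain and its oxygen for a single chlorine atom, or one halogen for the other, leaves compounds 2, 3 and 4 unseparated in this assay. Nothing on hand offers a reason for this lack of separation.

Whether a group of another kind at this carbon, such as an amine, a carboxylic acid or a longer alkoxy chain, would give a step beyond the scatter remains open, as all three groups shown leave the numbers within it. As far as these compounds go, compound 1 gives "not determined" (no result reported) in this assay so the exchange of its isopropyl for an aryl group on the triazole nitrogen cannot be read, and the value of having an aromatic ring at that nitrogen also stays open.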